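Pyridin-4-yl for Phenyl on the Carbonyl Carbon

The source may hold more compounds than are shown below. What is called first, only, known or untested is meant among the compounds shown, and "the series" means these compounds.

The measured compounds and their values:
Compound 1, `O=C(NN=C(c1ccccn1)c1ccccn1)c1ccncc1`: 830 nM
Compound 2, `O=C(NN=C(c1ccccn1)c1ccccn1)c1ccccc1`: 3040 nM
Compound 3, `C/C(=N\NC(=O)c1ccccc1)c1cnccn1`: 3620 nM

All three were examined in an ADME assay on cells (Homo sapiens) for antiproliferative activity, read by MTT assay; a lower number here means a stronger inhibitor, a higher number a weaker inhibitor. Compound 1 and compound 2 share one core and differ in a single place: pyridin-4-yl in place of phenyl on a carbonyl carbon. That change gave a 3.7-fold lower number from compound 2 to compound 1 (0.56 log units; beyond the scatter), a step beyond the scatter.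

Compound 3 carries a different core; how it differs from compound 2 is not broken down here. The values of compound 3 and compound 2 lie within the scatter of each other, so nothing is said of their order. Compound 1 gives a number well below that of compound 3.

Compound 4, `C/C(=N\NC(=O)c1ccncc1)c1cnccn1`, has not yet been measured. Among the compounds with values here, it differs from compound 3 by pyridin-4-yl in place of phenyl on a carbonyl carbon, which is the same change as the one from compound 2 to compound 1, at the same place on the carbonyl carbon. Within the data shown here, the expectation for compound 4 rests on that single earlier step, which was seen on a different core, and a somewhat smaller step is expected, since the one example does not show how far the effect carries over. The expected step is a 2.8-fold lower number from compound 3 to compound 4 (0.44 log units; beyond the scatter). The estimate for compound 4 in this assay is 1300 nM, with a plausible range from 500 nM to 3600 nM.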

Compound 4, half-maximal inhibitory concentration in the Homo sapiens assay: 5790 nM
The estimate for compound 4 lay 4.5-fold (0.65 log units) below the measured number, outside the stated range (above it).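

In the Homo sapiens assay, pyridin-4-yl in place of phenyl on the carbonyl carbon gave a 1.6-fold higher number from compound 3 to compound 4 (0.20 log units; within the scatter), so on this core the change has no effect that can be told from the scatter. The gain seen on the other core therefore did not carry over, and the two steps differ from each other: the same change on two cores in the Homo sapiens assay, a 3.7-fold lower number (0.56 log units; beyond the scatter) from compound 2 to compound 1 and a 1.6-fold higher number (0.20 log units; within the scatter) from compound 3 to compound 4, 5.9-fold (0.77 log units) apart, beyond the scatter of two such steps In a physicochemical assay for lipophilicity (on this read-out higher numbers stand for higher lipophilicity and lower numbers for lower lipophilicity), compound 3 gives 1.9 and compound 4 gives 1.2 on this core. What the two pairs do not show is which feature of the two cores sets the steps apart, or whether the shift in the physicochemical assay, which the change did produce on this core, has any bearing on the result in cells: the measured partition coefficient of compound 3, 1.9, and of compound 4, 1.2, a number 0.70 log units lower (beyond the scatter)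

With one pair on each core, the compounds shown cannot say which of the two steps is the more typical, or how the change would fare on a third core. On these data alone, on the carbonyl carbon they carry only phenyl and pyridin-4-yl, so it remains open whether a phenyl ring bearing an amine or a carboxylic acid would follow the same course on both cores or would also depend on the core.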